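Dibromination of a hydroxybenzamide sulfurtransferase inhibitor

This account rests on a few compounds, and the source may have more. Where it says the series, first, only, none or still open, it means among the compounds named here.

Measured compounds in an assay on isolated protein for inhibition of thiosulfate sulfurtransferase (Homo sapiens), with a stated time of 60 min, in the absence of a further agent; a higher number here means a weaker inhibitor, a lower number a stronger inhibitor:
Compound 1 `COc1c(Br)cccc1C(=O)Nc1ccc(Sc2nc3ccccc3s2)cc1` gives > 100000 nM, which is a limit of the assay rather than a number.
Compound 2 `O=C(Nc1ccc(Sc2nc3ccccc3s2)c(Cl)c1)c1cc(Br)cc(Br)c1O` gives > 100000 nM, again a limit of the assay.
Compound 3 `O=C(Nc1ccc(Sc2nc3ccccc3s2)cc1)c1cccc(Br)c1O` gives > 100000 nM, also a limit of the assay.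

Compound 3 therefore stands at the same limit as the other two measured compounds; no number separates it from them. Among the compounds with values here, the one step among measured compounds that differs in a single place, a step that the two limits leave unreadable from compound 1 to compound 3, cannot be read because both ends sit at a limit, and the limit of > 100000 nM in this assay, at which 3 of the 3 values shown sit, shows that every value so far sits there.

Compound 4 `O=C(Nc1ccc(Sc2nc3ccccc3s2)cc1)c1cc(Br)cc(Br)c1O` differs from compound 3 by bromo in place of hydrogen on an aromatic carbon. Compound 2 carries the same two bromo groups on its hydroxyphenyl part, with an added chloro group elsewhere, and it too reached only the limit. Within the data shown here, no measured step gives a size for adding a bromo group here, so no shift beyond the scatter can be expected in this assay, and the most likely outcome is once more a limit.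

The expected step is a step that the limit leaves unreadable from compound 3 to compound 4, essentially none. Compound 4 is expected to give about 150000 nM, with a range from 40000 nM to 600000 nM.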

Compound 4, half-maximal inhibitory concentration: > 100000 nM
Compound 4 ended at the assay's limit; the forecaster's own chance of this, stated with the estimate: 85%; the middle value lies beyond the limit too.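

In this assay compound 4 gives a limit and not a number, as do compound 1, compound 2 and compound 3, so no step among these compounds can be read: the limit of > 100000 nM in this assay, at which 4 of the 4 values shown sit. The compounds shown leave open how strongly any of the four inhibits the enzyme, and whether swapping the bromo, chloro, hydroxy or methoxy groups changes that at all.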